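Thiophene to Dimethoxyphenyl on the Enone of Compound 3

A few compounds are considered here, and "the series" means these few. Any claim that something is new, unique, unknown or untested is made for them only; others in the source may bear on it.

Measured compounds:
- compound 1 `O=C(/C=C/c1cn(-c2ccccc2)nc1-c1cccnc1)c1ccsc1` — in a functional assay on Huh-7 cells (Homo sapiens) for inhibition, read by sulforhodamine B assay, with a stated time of 72 h (a higher number here means a weaker inhibitor, a lower number a stronger inhibitor), compound 1 gives 1700 nM
- compound 2 `COc1ccc(OC)c(C(=O)/C=C/c2cn(-c3ccccc3)nc2-c2cccnc2)c1` — in this assay compound 2 gives 1300 nM
- compound 3 `O=C(/C=C/c1cn(-c2ccccc2)nc1-c1ccncc1)c1ccsc1` — in this assay compound 3 gives 2200 nM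

Compound 3 sits within the scatter of both companions: the step of a 1.3-fold higher number from compound 1 to compound 3 (0.11 log units; within the scatter) is small, and its gap to compound 2 is likewise one the scatter covers. The unmeasured compound 4 `COc1ccc(C(=O)/C=C/c2cn(-c3ccccc3)nc2-c2ccncc2)c(OC)c1` differs from compound 3 in one place: 2,4-dimethoxyphenyl in place of thiophen-3-yl on a carbonyl carbon.

Within the data shown here, one measured step bears on this change directly. Going from compound 1 to compound 2 swaps the same thiophen-3-yl for a dimethoxyphenyl on the carbonyl carbon, and that step was a 1.3-fold lower number from compound 1 to compound 2 (0.12 log units; within the scatter), within the scatter. Among the measured compounds shown here, the dimethoxyphenyl of compound 4 carries its methoxy groups in a different arrangement, for which no measured pair exists. On the evidence available, no shift beyond the scatter is expected in this assay, with a slight lean toward a lower number.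

Compound 4 is therefore expected at 1700 nM, with a range of 800 nM to 3600 nM, a step of a 1.3-fold lower number from compound 3 to compound 4 (0.11 log units; within the scatter).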

Compound 4, half-maximal inhibitory concentration: 4400 nM
Compound 4: middle estimate off by 2.6-fold (0.41 log units), on the low side; measured number above the stated range.
By their numbers in this assay, from the lowest: compounds 2, 1, 3 and 4 (each within the scatter of the next, the first and the last beyond it).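

In this assay the swap of thiophen-3-yl for 2,4-dimethoxyphenyl on the carbonyl carbon gives a 2.0-fold higher number from compound 3 to compound 4 (0.30 log units; within the scatter) among the pyridin-4-yl compounds, so this position takes the six-membered carbon ring with its methoxy groups without a shift beyond the scatter. Read beside a 1.3-fold lower number from compound 1 to compound 2 (0.12 log units; within the scatter) among the pyridin-3-yl compounds, this makes two swaps of thiophen-3-yl for a dimethoxyphenyl at this carbon that both stay within the scatter, each with its own methoxy arrangement and its own pyridine. No measurement at hand explains the result.

The compounds shown leave open whether the methoxy arrangement or the pyridine decides how such a swap reads, as the two swaps differ in both. They also leave open how a plain phenyl, or a phenyl carrying an amine or a carboxylic acid, would read on this carbonyl carbon.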